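A few compounds are considered here, and "the series" means these few. Any claim that something is new, unique, unknown or untested is made for them only; others in the source may bear on it.

Compound 2 `Nc1nc(NCCNc2ncc(-c3ncc[nH]3)c(-c3cc(F)ccc3F)n2)ccc1[N+](=O)[O-]` has been measured in an ADME assay on microsomes from liver (Canis lupus familiaris) for metabolic stability (on this read-out higher numbers stand for a longer-lived compound and lower numbers for a shorter-lived compound), only as far as a limit: compound 2 gives > 0.5 h, which is a limit of the assay and not a number. Compound 1 `N#Cc1ccc(NCCNc2ncc(-c3ncc[nH]3)c(-c3ccc(Cl)cc3Cl)n2)nc1` likewise reaches only a limit, giving > 0.5 h in this assay. Both results sit at the limit of > 0.5 h in this assay, at which 2 of the 2 values shown sit. Compound 3 `Cc1cc(Cl)ccc1-c1nc(NCCNc2ccc([N+](=O)[O-])c(N)n2)ncc1-c1ncc[nH]1` differs from compound 2 in one place: 4-chloro-2-methylphenyl in place of 2,5-difluorophenyl on an aromatic carbon. Going by the values given here, no step between measured compounds is available, so in this assay the change is expected to stay within the usual scatter, as a step that the limit leaves unreadable from compound 2 to compound 3. Compound 3 is therefore estimated at about 1 h, in a range from 0.4 h to 3 h.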

Compound 3, half-life: > 0.5 h
Compound 3 gave a limit, no number (the forecaster's own chance of this, stated with the estimate: 70%); the middle value is on the limit's open side.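

Compound 2 and compound 3 both reach only a limit in this assay, so no step between them can be read: the limit of > 0.5 h in this assay, at which 3 of the 3 values shown sit.

Going by these compounds, the true half-lives of compound 1, compound 2 and compound 3 stay open, as does whether 4-chloro-2-methylphenyl in place of 2,5-difluorophenyl changes the half-life.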